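The source may report more compounds than this note shows. Statements on the series, on what has been measured and on what is new or still open speak of the compounds shown alone.

Measured so far:
compound 1 `CCC(C)n1cnc2c(NCc3ccc(C(=O)Nc4ccccc4N)cc3)nc(Cl)nc21` – in a functional assay on NCI-H460 cells (Homo sapiens) for antiproliferative activity, read by CCK-8 assay, with a stated time of 72 h, tested at 2 uM (a lower number here means a weaker effect, a higher number a stronger effect of the compound at the concentration tested), compound 1 gives 47.3%
compound 2 `CCCCn1cnc2c(NCc3ccc(C(=O)Nc4ccccc4N)cc3)nc(Cl)nc21` – in this assay compound 2 gives 19.7%

Among the measured compounds shown here, compound 2 stands lowest of the two numbers; the only step, a number 27.6 percentage points lower from compound 1 to compound 2 (beyond the scatter), separates it from compound 1. Compound 3 `CCCn1cnc2c(NCc3ccc(C(=O)Nc4ccccc4N)cc3)nc(Cl)nc21` differs from compound 2 by hydrogen in place of methyl on a saturated chain carbon, three bonds along the chain from an aromatic nitrogen. For the measured compounds named here, no measured step shortens this chain; the one known step, a number 27.6 percentage points lower from compound 1 to compound 2 (beyond the scatter), changed branching rather than length, so it bears only loosely. In this assay a modest step in either direction, or none beyond the scatter, is expected. Compound 3 is expected to give 25%, between 5% and 50%. That means an estimated step of a number 5.3 percentage points higher from compound 2 to compound 3 (within the scatter).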

Compound 3, a percentage reported as inhibition, at one concentration (the size of the read-out at that concentration, not a potency): 31%
For compound 3 the middle estimate is 6 percentage points below the measured one; the range from low to high includes it.
By their numbers in this assay, from the lowest: compound 2; then compound 3; then compound 1.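

In this assay, the length of the unbranched chain on the aromatic nitrogen matters by itself: butyl to propyl, with no change in branching, gives a number 11.3 percentage points higher from compound 2 to compound 3 (beyond the scatter). Replacing sec-butyl with propyl still gives a number 16.3 percentage points lower from compound 1 to compound 3 (beyond the scatter), so compound 3 lies below the branched compound 1 and above compound 2, and compound 1 goes against any reading by chain length alone. What the compounds shown leave open is whether ethyl, a longer chain such as pentyl, or a cyclopentyl ring would extend this order. Nothing given here explains these steps.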